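Acid-bearing group variation on the shared core

The compounds below may be only part of what the source reports. "The series", "measured", "known", "first", "only" and "open" are said of these compounds alone.

compound 1 `COC(C(=O)O)c1nn(Cc2cn3cc(OCC4CC4)c(Cl)cc3n2)c2ccccc2c1=O`: 58 nM
compound 2 `O=C(O)C1(c2nn(Cc3cn4cc(OCC5CC5)c(Cl)cc4n3)c3ccccc3c2=O)CC1`: 82 nM

In a functional assay on CHO cells for antagonist activity at sphingosine 1-phosphate receptor 2 (Homo sapiens), read by GTPgammaS binding (on this read-out lower numbers stand for stronger inhibition and higher numbers for weaker inhibition), compound 2 gives 82 nM and stands alongside compound 1, the only other number shown; the step of a 1.4-fold higher number from compound 1 to compound 2 (0.15 log units; within the scatter) does not separate them. Compound 3 `CC(C)(C(=O)O)c1nn(Cc2cn3cc(OCC4CC4)c(Cl)cc3n2)c2ccccc2c1=O` differs from compound 2 by 1-carboxy-1-methylethyl in place of 1-carboxycyclopropyl on an aromatic carbon. Among the measured compounds shown here, the one step that bears on this exchange is a 1.4-fold higher number from compound 1 to compound 2 (0.15 log units; within the scatter), which also swapped the acid-bearing group and stayed within the scatter, so no step beyond the scatter is expected in this assay. Compound 3 is therefore estimated at 80 nM, within 35 nM to 190 nM, an expected step of a 1.0-fold lower number from compound 2 to compound 3 (0.01 log units; within the scatter).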

Compound 3, half-maximal inhibitory concentration: 105 nM
Compound 3: the middle estimate sits 1.3-fold (0.12 log units) below what was measured, and the stated range covers the measured number.
By their numbers in this assay, from the lowest: compounds 1, 2 and 3 (each within the scatter of the next).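

In this assay, 1-carboxy-1-methylethyl in place of 1-carboxycyclopropyl gives a 1.3-fold higher number from compound 2 to compound 3 (0.11 log units; within the scatter), so on this aromatic carbon the three-membered ring can be absent without a step beyond the scatter. The step of a 1.8-fold higher number from compound 1 to compound 3 (0.26 log units; within the scatter) is also within the scatter, which leaves the three acid-bearing groups unseparated. No measurement shown offers an explanation for these steps.

Still open, on these data alone, is whether a primary amide or a tetrazole in place of the carboxylic acid would separate from these three. A longer chain between the acid and the aromatic carbon is equally untested by the compounds shown.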